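Notes on halogen swaps on the pendant phenyl ring

This account rests on a few compounds, and the source may have more. Where it says the series, first, only, none or still open, it means among the compounds named here.

Three compounds of the shared core have been run in a functional assay on PC-3 cells (Homo sapiens) for inhibition, read by MTT assay, with a stated time of 72 h, tested at 1 uM; a higher number here means more inhibition of growth at the concentration tested, a lower number less inhibition of growth. Compound 1 `COc1cc2ncnc(Nc3cccc(C(F)(F)F)c3)c2c(OC)c1OC` gives 14.9%. Compound 2 `COc1cc2ncnc(Nc3cc(C(F)(F)F)ccc3Br)c2c(OC)c1OC` gives -3.9%. Compound 3 `COc1cc2ncnc(Nc3ccc(Br)cc3Cl)c2c(OC)c1OC` gives -8.4%, the lowest of the three numbers; its gap to compound 2 is within the scatter, while its gap to compound 1 is beyond it. Among the measured compounds shown here, the only single-point step so far is a number 18.8 percentage points lower from compound 1 to compound 2 (beyond the scatter), a modest drop.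

Compound 4 `COc1cc2ncnc(Nc3ccc(F)cc3)c2c(OC)c1OC` is not yet measured. The change from compound 3 is 4-fluorophenyl in place of 4-bromo-2-chlorophenyl on a nitrogen on an aromatic ring. For the measured compounds named here, no measured step covers this exact exchange. Going by the values given here, the one bearing step, from compound 1 to compound 2, is the addition of a bromo and lowered the number beyond the scatter; compound 4 goes the other way, carrying neither bromo nor chloro but a single fluoro, and compound 1, the compound without bromo or chloro, sits highest. A modest rise is therefore expected, with the step from compound 3 to compound 4 estimated at a number 16.4 percentage points higher from compound 3 to compound 4 (beyond the scatter) in this assay. Compound 4 is expected to give about 8% in this assay, within a range from -8% to 24%.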

Compound 4, percent growth inhibition at one concentration: 3.1%
Beside the measured number, compound 4's estimate is 4.9 percentage points above it; the measured number falls inside the stated range.
By their numbers in this assay, from the lowest: compounds 3, 2 and 4 (each within the scatter of the next, the first and the last beyond it); then compound 1.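

In this assay, among the compounds shown here, the exchange of 4-bromo-2-chlorophenyl for 4-fluorophenyl on a nitrogen on an aromatic ring gives a number 11.5 percentage points higher from compound 3 to compound 4 (beyond the scatter), the first step that rises and the first to replace the whole pendant ring rather than add one halogen to it. Set against the earlier drop on adding a bromo, a number 18.8 percentage points lower from compound 1 to compound 2 (beyond the scatter), this shows that the number at this position can move in both directions with the halogens carried, although the new step is modest and compound 4 still gives only 3.1% at the single concentration tested. No measurement available here accounts for the rise, so it remains an observed difference without an established cause.

This one exchange removes the bromo and the chloro and brings in the fluoro all at once, so the share of each in the step stays unresolved, as does whether a single bromo or chloro on the phenyl would behave like the fluoro. Also open, going by these compounds, is how the number would respond to a pendant ring carrying a non-halogen group such as a nitrile, an amine or a carboxylic acid.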